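A few compounds are considered here, and "the series" means these few. Any claim that something is new, unique, unknown or untested is made for them only; others in the source may bear on it.

Compound 1 `O=S(=O)(Nc1ccc(-c2nc3ccccc3o2)cc1)c1ccc(Cl)s1` gives 31000 nM in an assay on cells for inhibition of HSP60/HSP10 (Homo sapiens), with a stated time of 60 min; on this read-out lower numbers stand for stronger inhibition and higher numbers for weaker inhibition.
Compound 2 `C=Cc1ccc(S(=O)(=O)Nc2ccc3oc(-c4ccccc4)nc3c2)cc1` gives only a limit of this assay, > 100000 nM.
Compound 3 `O=S(=O)(Nc1ccc(-c2nc3ccccc3o2)cc1)c1ccccc1F` gives only a limit of this assay, > 100000 nM.

Compound 2 thus stands at the limit of this assay, not at a number, and it is not alone there: the limit of > 100000 nM in this assay, at which 2 of the 3 values shown sit. Compound 4 `O=S(=O)(Nc1ccc2oc(-c3ccccc3)nc2c1)c1cccc(O)c1` differs from compound 2 in one place: 3-hydroxyphenyl in place of 4-vinylphenyl on a sulfonyl sulfur. Going by the values given here, the one measured step that changes the group on the sulfonyl sulfur is an at least 3.2-fold higher number from compound 1 to compound 3 (0.50 log units; beyond the scatter), but both groups there differ from the two here, and the sulfonamide sits on a different part of the shared core, so it bears only loosely on this change. Among the compounds with values here, it does show that a new group at this place can weaken binding beyond the scatter, and no measured step shows a strengthening. Because compound 2 already gives the limit > 100000 nM, any further weakening could not be seen. Compound 4 is therefore expected near that limit, estimated at 100000 nM with a range from 30000 nM to 300000 nM. The expected step is a number no higher from compound 2 to compound 4 (the limit leaves the size open), which is none that can be told from the scatter.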

Compound 4, half-maximal inhibitory concentration: 76000 nM
Estimate against measurement, compound 4: 1.3-fold (0.12 log units) above, within the range that was stated.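

With 3-hydroxyphenyl on the sulfonyl sulfur, the core of compound 2 now gives a measured number rather than a limit: compound 4 gives 76000 nM. Going by these compounds, the step is an at least 1.3-fold lower number from compound 2 to compound 4 (0.11 log units; that floor lies within the scatter), so replacing 4-vinylphenyl shows no proven gain, although the true size of the step remains unknown. The number does give this core a usable reference point, as a later step from compound 4 could be read in either direction, whereas a step from compound 2 could not.

On these data alone, what a plain phenyl, a methoxyphenyl or an aminophenyl would give on this sulfonyl sulfur stays open, so the number cannot be tied to the hydroxyl itself. Also open, as far as these compounds go, is how the 5-chlorothiophen-2-yl group of compound 1 would fare on the core of compound 4.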